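Pyridin-2-ylamino side chain on the shared piperidine core

This account rests on a few compounds, and the source may have more. Where it says the series, first, only, none or still open, it means among the compounds named here.

Of the compounds shown here, three with the same core have been measured in an assay on CHO cells for displacement of a labelled ligand from 5-hydroxytryptamine receptor 1D (Homo sapiens); on this read-out lower numbers stand for stronger inhibition and higher numbers for weaker inhibition. Compound 1 `CC(C)=CCCN(C)C1CCN(CCCc2c[nH]c3ccc(-n4cnnc4)cc23)CC1` gives 2.6 nM; compound 2 `CC(=O)Nc1ccc([C@@H](C)NCC2CCN(CCCc3c[nH]c4ccc(-n5cnnc5)cc34)CC2)cc1` gives 1.5 nM; compound 3 `C[C@H](NCC1CCN(CCCc2c[nH]c3ccc(-n4cnnc4)cc23)CC1)c1ccccc1` gives 4.4 nM. Compound 1 thus holds the second highest number of the three, with compound 3 and compound 2 both within the scatter of it, so no order among them can be claimed.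

Compound 4 `c1ccc(NCC2CCN(CCCc3c[nH]c4ccc(-n5cnnc5)cc34)CC2)nc1` has not yet been measured. It differs from compound 1 in one place: ((pyridin-2-yl)amino)methyl in place of methyl(4-methylpent-3-en-1-yl)amino on a saturated ring carbon. The closest measured parallel is the change from compound 1 to compound 3, where a ((1-phenylethyl)amino)methyl group likewise replaces the methyl(4-methylpent-3-en-1-yl)amino group, and that step was a 1.7-fold higher number from compound 1 to compound 3 (0.23 log units; within the scatter). A further hint comes from a 2.9-fold higher number from compound 2 to compound 3 (0.47 log units; beyond the scatter), which shows that the aryl part of such a side chain can shift the number modestly. On this basis a small step is expected, within or just beyond the scatter, most likely toward a somewhat higher number, as a 1.7-fold higher number from compound 1 to compound 4 (0.24 log units; within the scatter). Compound 4 is therefore estimated at 4.5 nM, with a range from 1.5 nM to 14 nM.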

Compound 4, half-maximal inhibitory concentration: 1.7 nM
Compound 4: middle estimate off by 2.6-fold (0.42 log units), on the high side, and the stated range covers the measured number.
By their numbers in this assay, from the lowest: compounds 2, 4, 1 and 3 (each within the scatter of the next, the first and the last beyond it).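

The change at this saturated ring carbon, three ring bonds from the ring nitrogen, brings in a six-membered aromatic ring and a hydrogen-bond donor, yet in this assay it gives only a 1.5-fold lower number from compound 1 to compound 4 (0.18 log units; within the scatter). For the compounds shown here, on the amine nitrogen, pyridin-2-yl also stands level with the larger 1-(4-acetamidophenyl)ethyl group, with a 1.1-fold higher number from compound 2 to compound 4 (0.05 log units; within the scatter), so the acetamide of compound 2 is not needed to reach a number of this size, while replacing 1-phenylethyl with pyridin-2-yl gives a 2.6-fold lower number from compound 3 to compound 4 (0.41 log units; beyond the scatter), the only one of these steps beyond the scatter. No measurement shown here gives a reason for any of these steps.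

Going by these compounds, it remains open whether the ring nitrogen of pyridin-2-yl contributes to the number in this assay, a question that a plain phenyl or a pyridin-3-yl on the same amine nitrogen would address. On these data alone, it is equally open whether the amine hydrogen matters, which an N-methyl amine in the ((pyridin-2-yl)amino)methyl side chain would test.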